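Swapping an Open Chain for a Cyclohexyl Ring

A few compounds are considered here, and "the series" means these few. Any claim that something is new, unique, unknown or untested is made for them only; others in the source may bear on it.

In an ADME assay on microsomes from liver (Rattus norvegicus) for metabolic stability (on this read-out lower numbers stand for a less stable compound and higher numbers for a more stable compound), compound 1 (`C/C(=C/CN(C[C@H]1Cc2ccccc2CN1)[C@H]1CCCc2cccnc21)CN`) gives 1% and compound 2 (`C/C(CN(C[C@H]1Cc2ccccc2CN1)[C@H]1CCCc2cccnc21)=C(\F)CN`) gives 6%, so the two stand level within the scatter. Among the compounds with values here, the single measured step, a number 5 percentage points higher from compound 1 to compound 2 (within the scatter), is small and also falls on the open chain attached to the amine nitrogen. Compound 3 (`N[C@H]1CC[C@H](N(C[C@H]2Cc3ccccc3CN2)[C@H]2CCCc3cccnc32)CC1`) carries 4-aminocyclohexyl in place of 4-amino-3-fluoro-2-methylbut-2-en-1-yl on an amine nitrogen. Within the data shown here, no measured step replaces this chain with a ring, so the available data give only weak guidance. Since compound 2 shows 6%, little room remains for a fall, and any sizeable move would be expected upward. The expected change is small, with the estimated step being a number 4 percentage points higher from compound 2 to compound 3 (within the scatter). For compound 3 the estimated value is 10%, with an expected range from 1% to 30%.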

Compound 3, percent of the compound remaining: 71%
Estimate against measurement, compound 3: 61 percentage points below, and the stated range ends below it.
By their numbers in this assay, from the lowest: compounds 1 and 2 (each within the scatter of the next); then compound 3.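

On the amine nitrogen whose other neighbours are a saturated chain carbon and a saturated ring carbon, the two open chains stood level in this assay, yet 4-aminocyclohexyl brings a number 65 percentage points higher from compound 2 to compound 3 (beyond the scatter) and a number 70 percentage points higher from compound 1 to compound 3 (beyond the scatter), so this position responds strongly to the group it carries. 4-Aminocyclohexyl and 4-amino-3-fluoro-2-methylbut-2-en-1-yl match in heavy atoms and in hydrogen-bond donors and acceptors, so the larger step comes with a six-membered carbon ring, and with the loss of the fluorine and the double bond, rather than with a change in those counts. No measurement shown here gives a cause for this rise.

The compounds shown leave open whether the ring itself matters or only the loss of the fluorine and the double bond, which a saturated open chain such as 4-aminobutyl on the same nitrogen would help to separate. They also leave open whether the amine on the ring is needed, as a plain cyclohexyl or a 4-hydroxycyclohexyl group would show.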